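The source may report more compounds than this note shows. Statements on the series, on what has been measured and on what is new or still open speak of the compounds shown alone.

For the measured compounds named here, compound 1, with structure `CC(=O)O[C@H]1CC[C@]2(C)[C@H](CC[C@@](C)(O)[C@H]2CC[C@@H]2C(C)=CC[C@H]3[C@H](CC[C@]3(C)O)C2(C)C)OC1(C)C`, is the only compound of this pair for which a number is reported: in a functional assay on MCF7 cells (Homo sapiens) for antiproliferative activity, read by MTT assay, with a stated time of 72 h (a lower number here means a stronger inhibitor, a higher number a weaker inhibitor), compound 1 gives 47900 nM. Compound 2, with structure `CC1=CC[C@H]2[C@H](CC[C@]2(C)O)C(C)(C)[C@@H]1CC[C@H]1[C@]2(C)CC/C(=N/OCc3ccccc3)C(C)(C)O[C@H]2CC[C@@]1(C)O`, is reported only as a limit of the assay, > 50000 nM in this assay, so it provides no number. This leaves compound 1 standing alone among the numbers shown, beside (the limit of > 50000 nM in this assay, at which 1 of the 2 values shown sits), and no step between two measured compounds is available to guide expectations.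

Compound 3, with structure `CC1=CC[C@H]2[C@H](CC[C@]2(C)O)C(C)(C)[C@@H]1CC[C@H]1[C@]2(C)CC[C@H](OC(=O)c3ccc(C(F)(F)F)cc3F)C(C)(C)O[C@H]2CC[C@@]1(C)O`, shares the core of compound 1 and differs from it in one place: 2-fluoro-4-(trifluoromethyl)phenyl in place of methyl on a carbonyl carbon. Going by the values given here, with no measured step of comparable kind, the size of the step in this assay from compound 1 to compound 3 is expected to be modest, most likely toward stronger inhibition but possibly no larger than the scatter. The step of a 2.4-fold lower number from compound 1 to compound 3 (0.38 log units; beyond the scatter) is therefore the estimate. Compound 3 is expected to give about 20000 nM in this assay, within a range from 5000 nM to 60000 nM.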

Compound 3, half-maximal inhibitory concentration: > 50000 nM
Compound 3 was reported as a limit; the forecaster's own chance of this, stated with the estimate: 25%; middle value at least 2.5-fold (0.39 log units) from the limit.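

In this assay, placing 2-fluoro-4-(trifluoromethyl)phenyl in place of methyl on this carbonyl carbon brought no gain in inhibition, and the step can be read only as a floor: an at least 1.0-fold higher number from compound 1 to compound 3 (0.01 log units; that floor lies within the scatter). The value of compound 3 is a limit of the assay and not a number, so how much weaker compound 3 is, if it is weaker at all, cannot be told. With this result, the limit holds more of the values than the numbers do: the limit of > 50000 nM in this assay, at which 2 of the 3 values shown sit.

As far as these compounds go, whether a dimethylaminomethyl group or a carboxylic acid on this carbonyl carbon would bring the number down remains open. So does the reading of a plain phenyl group, and without it the effect of the ring cannot be separated from that of its fluorine and trifluoromethyl substituents.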